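Second Chloro on the Benzyl Ether of Compound 2

The source may report more compounds than this note shows. Statements on the series, on what has been measured and on what is new or still open speak of the compounds shown alone.

Of the compounds shown here, two with a shared core have been measured so far. Compound 1 `Cc1ccc(NC(=S)NC(=O)c2ccc(OCc3ccc(Cl)cc3Cl)cc2)cc1-c1nc2ccccc2[nH]1` in a functional assay on SW-620 cells (Homo sapiens) for inhibition, read by MTT assay, with a stated time of 48 h (a lower number here means a stronger inhibitor, a higher number a weaker inhibitor), gives 57200 nM. Compound 2 `Cc1ccc(NC(=O)NC(=O)c2ccc(OCc3cccc(Cl)c3)cc2)cc1-c1nc2ccccc2[nH]1` in this assay gives 16000 nM. Compound 2 therefore stands at the lowest number of the two, and compound 1 sits at a higher number, a gap beyond the usual scatter. Compound 1 differs from compound 2 in more than one place at once, so the two values say nothing about any single change.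

Compound 3 `Cc1ccc(NC(=O)NC(=O)c2ccc(OCc3ccc(Cl)c(Cl)c3)cc2)cc1-c1nc2ccccc2[nH]1` is built from compound 2 by one change: chloro in place of hydrogen on an aromatic carbon, which turns the 3-chlorobenzyl group into a 3,4-dichlorobenzyl group. Among the compounds with values here, no measured pair isolates this change, so its size in this assay is open. Since the step adds one small atom to a group that compound 2 already carries, the expectation is a number close to that of compound 2, with a small gain counted as more likely than a loss. Compound 3 is estimated at 12000 nM, within a range from 4000 nM to 40000 nM. The expected step of a 1.3-fold lower number from compound 2 to compound 3 (0.12 log units; within the scatter) would fall within the scatter.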

Compound 3, half-maximal inhibitory concentration: 6100 nM
Compound 3: middle estimate off by 2.0-fold (0.29 log units), on the high side; measured number inside the range.
By their numbers in this assay, from the lowest: compound 3; then compound 2; then compound 1.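

Within the data shown here, the change from a 3-chlorobenzyl group to a 3,4-dichlorobenzyl group gives a 2.6-fold lower number from compound 2 to compound 3 (0.42 log units; beyond the scatter) in this assay, and this is the first effect of a single change that can be read in this set of compounds. It shows that this aromatic carbon, ortho to the existing chloro group and para to a large group, can carry a second chloro with a modest gain in inhibition rather than a loss, although the evidence is one pair of compounds on one core in one cell assay. No measurement given here explains why the number falls with this added chlorine atom.

The pair cannot show whether chlorine itself matters at this carbon, since fluoro, methyl, methoxy or nitrile groups in the same place are not among the compounds shown, and any of these might give a similar step, a larger one or a loss. It also leaves open whether the gain needs the first chloro group, and whether it would carry over to other compounds built on the shared core.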